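Swapping the anilino aryl group on a shared quinazoline-free core

This account rests on a few compounds, and the source may have more. Where it says the series, first, only, none or still open, it means among the compounds named here.

Two compounds share a common core and differ only in the aromatic group attached to a nitrogen on an aromatic ring. Compound 1 `CCS(=O)(=O)Nc1cc(-c2ccc3ncnc(Nc4ccc(F)cc4F)c3c2)cnc1OC` gives 2480 nM in a functional assay on BT-549 cells (Homo sapiens) for cytotoxicity, read by sulforhodamine B assay, with a stated time of 72 h (a lower number here means a stronger inhibitor, a higher number a weaker inhibitor), and compound 2 `CCS(=O)(=O)Nc1cc(-c2ccc3ncnc(Nc4cccc(C(=O)OC)c4)c3c2)cnc1OC` gives 1080 nM. Among the compounds with values here, the step is a 2.3-fold lower number from compound 1 to compound 2 (0.36 log units; beyond the scatter), so compound 2 stands as the lower of the two numbers, the only measured pair available.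

Compound 3 `CCS(=O)(=O)Nc1cc(-c2ccc3ncnc(Nc4ccc(F)nc4)c3c2)cnc1OC` carries the change (6-fluoropyridin-3-yl in place of 3-(methoxycarbonyl)phenyl on a nitrogen on an aromatic ring). Within the data shown here, no measured step covers this exact swap; the one step at the same place shows that moving away from a small, fluorinated aryl group toward the methoxycarbonyl-bearing phenyl lowered the number modestly. Returning to a smaller fluorinated ring is expected to move the number back up, in the direction of compound 1. For compound 3 the expected step is a 1.9-fold higher number from compound 2 to compound 3 (0.27 log units; within the scatter), and its estimated value in this assay is 2000 nM, with a range from 800 nM to 5000 nM.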

Compound 3, half-maximal inhibitory concentration: 4780 nM
The estimate for compound 3 lay 2.4-fold (0.38 log units) below the measured number; low and high end bracket the measured number.
By their numbers in this assay, from the lowest: compound 2; then compounds 1 and 3 (each within the scatter of the next).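

In this assay the group on this nitrogen now separates compounds by more than the scatter in a second comparison: 6-fluoropyridin-3-yl in place of 3-(methoxycarbonyl)phenyl gives a 4.4-fold higher number from compound 2 to compound 3 (0.65 log units; beyond the scatter) and leaves compound 2 with the lowest number of the three. The two fluorinated rings, by contrast, cannot be told apart, with a 1.9-fold higher number from compound 1 to compound 3 (0.28 log units; within the scatter) and so no readable effect of exchanging 2,4-difluorophenyl for 6-fluoropyridin-3-yl. Nothing available explains why the methoxycarbonyl-bearing ring stands apart from the other two.

Going by these compounds, it remains open whether the lower number of compound 2 depends on the methoxycarbonyl group itself or would also appear with a plain phenyl ring. A carboxylic acid or an amide in place of the methyl ester would help to separate these possibilities.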